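Methyl to hydrogen on the chain carbon of compound 1

The source may report more compounds than this note shows. Statements on the series, on what has been measured and on what is new or still open speak of the compounds shown alone.

Compound 1 `C[C@@H](C#Cc1cccc(C(=O)NCc2ccccc2C(F)(F)F)c1)N(O)C(N)=O` gives 700 nM in an assay for inhibition of Polyunsaturated fatty acid 5-lipoxygenase (Homo sapiens), read by HPLC, with stated times of 15 min and 10 min (on this read-out lower numbers stand for stronger inhibition and higher numbers for weaker inhibition), the highest of the three numbers. Compound 2 `C[C@H](C#Cc1cccc(C(=O)NCCC(c2ccc(F)cc2)c2ccc(C(F)(F)F)cc2)c1)N(O)C(N)=O` gives 220 nM and compound 3 `C[C@H](C#Cc1cccc(C(=O)NCC[C@H](c2ccc(F)cc2)c2ccc(C(F)(F)F)cc2)c1)N(O)C(N)=O` gives 230 nM; both stand beyond the scatter below compound 1. For the measured compounds named here, the single measured step, a 1.0-fold higher number from compound 2 to compound 3 (0.02 log units; within the scatter), rests only on the fact that one of compounds 2 and 3 is drawn with a defined configuration and the other without, at the place where they differ and says nothing about the chain carbon. Compound 4 `NC(=O)N(O)CC#Cc1cccc(C(=O)NCc2ccccc2C(F)(F)F)c1` differs from compound 1 by hydrogen in place of methyl on a saturated chain carbon bound to an amide-type nitrogen and a triple-bonded carbon. Going by the values given here, no measured pair alters this carbon, so neither direction nor size of the step is anchored by the series. The step is therefore expected to stay small: a 1.4-fold higher number from compound 1 to compound 4 (0.15 log units; within the scatter). The estimate for compound 4 is 1000 nM, with a wide range from 300 nM to 3500 nM.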

Compound 4, half-maximal inhibitory concentration: 4000 nM
The estimate for compound 4 lay 4.0-fold (0.60 log units) below the measured number; measured number above the stated range.
By their numbers in this assay, from the lowest: compounds 2 and 3 (each within the scatter of the next); then compound 1; then compound 4.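

In this assay, hydrogen in place of methyl on the saturated chain carbon bound to an amide-type nitrogen and a triple-bonded carbon gives a 5.7-fold higher number from compound 1 to compound 4 (0.76 log units; beyond the scatter), so this position responds to the change beyond the scatter. For the compounds shown here, the earlier compounds all carry the methyl, and this pair gives the first reading of the position: on the core of compound 1, the methyl goes with the lower number. Nothing available bears on the cause of this step.

As far as these compounds go, it remains open whether an ethyl group on this carbon would read nearer compound 1 or compound 4. From the compounds shown here alone, it is also open whether the same step would appear with the amide side chain of compound 2.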